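The source may report more compounds than this note shows. Statements on the series, on what has been measured and on what is new or still open speak of the compounds shown alone.

Compound 1 `CC(=O)N1CCN(c2nc(Nc3ccc(C#N)c(C(F)(F)F)c3)nc(Oc3ccnc4ccccc34)n2)CC1`: 75100 nM
Compound 2 `N#Cc1ccc(Nc2nc(Oc3ccnc4ccccc34)nc(N3CCN(C(c4ccccc4)c4ccc(Cl)cc4)CC3)n2)cc1C(F)(F)F`: > 100000 nM
Compound 3 `N#Cc1ccc(Nc2nc(Oc3ccnc4ccccc34)nc(N3CCN(Cc4ccccc4)CC3)n2)cc1C(F)(F)F`: > 100000 nM

Of the compounds shown here, three sharing one core have been tested in a functional assay on DU-145 cells (Homo sapiens) for cytotoxicity, read by sulforhodamine B assay, with a stated time of 48 h; a higher number here means a weaker inhibitor of growth, a lower number a stronger inhibitor of growth. Compound 1 gives 75100 nM in this assay. For compound 2 the result is a limit of this assay, > 100000 nM, and not a number. For compound 3 as well the result is only a limit, > 100000 nM. Compound 3 therefore stands at the limit of > 100000 nM in this assay, at which 2 of the 3 values shown sit, and nothing more than that limit is known of it.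

Two measured steps lead to compound 3. The step of an at least 1.3-fold higher number from compound 1 to compound 3 (0.12 log units; that floor lies within the scatter) is small and its floor lies within the scatter. The step that the two limits leave unreadable from compound 2 to compound 3 cannot be read, since both ends are limits.

Compound 4 `N#Cc1ccc(Nc2nc(Oc3ccnc4ccccc34)nc(N3CCN(C(c4ccccc4)c4ccccc4)CC3)n2)cc1C(F)(F)F` differs from compound 3 by phenyl in place of hydrogen on a saturated chain carbon bound to an amine nitrogen in a ring and an aromatic carbon. For the measured compounds named here, the nearest measured step is the one from compound 2 to compound 3, which adds or removes a related group at the same place, and that step is unreadable. With two of the three results at the limit, no step beyond the scatter can be expected in this assay; the step that the limit leaves unreadable from compound 3 to compound 4 is the estimate. Compound 4 is expected to give about 150000 nM, within 60000 nM to 400000 nM, most likely again as a limit.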

Compound 4, concentration for 50% growth inhibition: > 100000 nM
Compound 4: a limit, no number; the forecaster's own chance of this, stated with the estimate: 75%; the middle value lies beyond the limit too.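

Compound 4 gives only a limit in this assay, > 100000 nM, and not a number. The steps from compound 2 and from compound 3 to compound 4 therefore cannot be read. The compounds shown leave open whether compounds 2, 3 and 4 differ from one another at all, since the results reach no further than this: the limit of > 100000 nM in this assay, at which 3 of the 4 values shown sit.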